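The source may hold more compounds than are shown below. What is called first, only, known or untested is meant among the compounds shown, and "the series" means these compounds.

Of the compounds shown here, three of a shared core have been measured in a functional assay on MCF7 cells (Homo sapiens) for inhibition, read by sulforhodamine B assay, with a stated time of 48 h, tested at 50 uM; a lower number here means less inhibition of growth, a higher number more inhibition of growth at the concentration tested. Compound 1 `COc1ccc([C@@H]2C/C(=N/OCc3cn(-c4ccc(Cl)cc4C)nn3)c3cc(CC=C(C)C)c(OC)cc3O2)cc1` gives 37%. Compound 2 `COc1cc2c(cc1CC=C(C)C)C(=O)C[C@@H](c1ccc(Oc3ccc(F)cc3)cc1)O2` gives 37%, level with compound 1 at the digits shown, and these two together stand as the lowest of the three numbers. Compound 3 `COc1ccc([C@@H]2C/C(=N/O)c3cc(CC=C(C)C)c(OC)cc3O2)cc1` gives 63%, a higher number than compound 2, and that difference lies beyond the scatter of this assay.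

Compound 4 `C#CCOc1ccc([C@@H]2CC(=O)c3cc(CC=C(C)C)c(OC)cc3O2)cc1` has not yet been measured in this assay. It differs from compound 2 in one place: propargyl in place of 4-fluorophenyl on an oxygen on an aromatic ring. Compound 3 carries a small group on the corresponding oxygen and gives the highest of the three numbers, while compound 2 with its 4-fluorophenyl gives one of the two lowest, so a smaller group at that oxygen goes along with the higher number in this set, though compound 1 and compound 3 differ in more than this one place and the comparison is not clean.

On that basis the step of a number 9 percentage points higher from compound 2 to compound 4 (within the scatter) is expected to be a small rise, possibly no larger than the scatter. Compound 4 is estimated at 46%, with a range from 28% to 66%.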

Compound 4, percent growth inhibition at one concentration: 68%
The estimate for compound 4 lay 22 percentage points below the measured number, outside the stated range (above it).
By their numbers in this assay, from the lowest: compounds 1 and 2 (each within the scatter of the next); then compounds 3 and 4 (each within the scatter of the next).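

In this assay, propargyl in place of 4-fluorophenyl on an oxygen on an aromatic ring gives a number 31 percentage points higher from compound 2 to compound 4 (beyond the scatter). Among the compounds shown here, this is a large step and the only comparison in the set where a single place changes, so it isolates the effect of this position in a way the earlier compounds could not. It shows that the group on this oxygen can strongly affect the read-out, at least for this pair, with 3 heavy atoms and a triple bond standing in place of 7 heavy atoms and a six-membered aromatic ring; nothing measured here offers an explanation for the step.

This single step cannot separate the loss of the aromatic ring from the drop in heavy atoms or the arrival of the triple bond, and a propyl chain, with no triple bond, or a phenyl without the fluorine on the same oxygen would begin to pull these apart. It also leaves open whether the change would give a step of similar size on a compound such as compound 3, which differs from compound 4 in more than one place.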